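Hexylsulfanyl on the shared core: tolerance in HFF cells

The compounds below may be only part of what the source reports. "The series", "measured", "known", "first", "only" and "open" are said of these compounds alone.

- Compound 1 `Nc1nc(OCC(F)(F)F)c2ncn(/C=C3/CC3(CO)CO)c2n1`: > 300000 nM, a limit
- Compound 2 `CC(C)Nc1nc(N)nc2c1ncn2/C=C1/CC1(CO)CO`: > 300000 nM, a limit
- Compound 3 `Nc1nc(N2CCCC2)c2ncn(/C=C3/CC3(CO)CO)c2n1`: > 300000 nM, a limit

In an ADME assay on HFF cells (Homo sapiens) for cytotoxicity, with a stated time of 8 days (a lower number here means that less compound is tolerated, a higher number that more compound is tolerated), compound 3 gives > 300000 nM, which is a limit and not a number. Among the measured compounds shown here, all the compounds measured so far share this position: the limit of > 300000 nM in this assay, at which 3 of the 3 values shown sit.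

Compound 4 `CCCCCCSc1nc(N)nc2c1ncn2/C=C1/CC1(CO)CO` carries hexylsulfanyl in place of pyrrolidin-1-yl on an aromatic carbon.

Three measured changes at this same carbon bear on the step: a step that the two limits leave unreadable from compound 1 to compound 2, a step that the two limits leave unreadable from compound 1 to compound 3 and a step that the two limits leave unreadable from compound 2 to compound 3. For the measured compounds named here, none of them gives a size to carry over, and no measured compound holds a hexylsulfanyl group. The three substituents tried so far have not brought any compound off the limit, so compound 4 may well stay there too. Going by the values given here, a move towards less tolerated compound is still allowed for, since the entering chain has no measured counterpart.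

The expected change is an at least 2.5-fold lower number from compound 3 to compound 4 (0.39 log units; beyond the scatter), and its size is only loosely estimated. For compound 4 the estimate is 120000 nM, with an expected range of 30000 nM to 300000 nM.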

Compound 4, half-maximal cytotoxic concentration: > 300000 nM
Compound 4: only a limit was reported; the forecaster's own chance of this, stated with the estimate: 40%; middle value at least 2.5-fold (0.39 log units) away from the limit.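

Compound 4 ends at a limit, like compound 1, compound 2 and compound 3, so no step among these four can be read in this assay: the limit of > 300000 nM in this assay, at which 4 of the 4 values shown sit. The compounds shown leave open what number lies behind each limit and whether any substituent at this aromatic carbon changes tolerance.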